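A few compounds are considered here, and "the series" means these few. Any claim that something is new, unique, unknown or untested is made for them only; others in the source may bear on it.

In a functional assay on U-937 cells (Homo sapiens) for cytotoxicity, read by MTT assay, with a stated time of 3 days (on this read-out lower numbers stand for stronger inhibition and higher numbers for weaker inhibition), compound 1 (`N#Cc1c(Cl)nc(SCc2nc3ccccc3[nH]2)nc1-c1ccccc1`) gives 4.46 nM while compound 2 (`N#Cc1c(Nc2ccccc2)nc(SCc2nc3ccccc3[nH]2)nc1-c1ccccc1`) gives 3.28 nM and compound 3 (`CCNc1nc(SCc2nc3ccccc3[nH]2)nc(-c2ccccc2)c1C#N`) gives 2.63 nM on the same read-out. Compound 3 stands level with the other two, with a 1.2-fold lower number from compound 2 to compound 3 (0.10 log units; within the scatter) and a 1.7-fold lower number from compound 1 to compound 3 (0.23 log units; within the scatter) on record. The remaining measured step, a 1.4-fold lower number from compound 1 to compound 2 (0.13 log units; within the scatter) as well, involves the same carbon substituent. Among the compounds with values here, the change to compound 4 (`N#Cc1c(NNC(N)=S)nc(SCc2nc3ccccc3[nH]2)nc1-c1ccccc1`) is a group of 4 heavy atoms (1 carbon, 2 nitrogen, 1 sulfur; no ring) in place of a group of 2 heavy atoms (2 carbon; no ring), on a nitrogen on an aromatic ring and no measured compound carries this group. All three measured steps stayed small, so no step beyond the scatter is expected in this assay though this rests on few compounds. The estimated move is a 1.3-fold higher number from compound 3 to compound 4 (0.12 log units; within the scatter) as expected from these steps. Compound 4 is expected at 3.5 nM within an estimated range of 1.3 nM to 10 nM on this read-out.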

Compound 4, half-maximal inhibitory concentration: 3 nM
Beside the measured number, compound 4's estimate is 1.2-fold (0.07 log units) above it; the measured number falls inside the stated range.
By their numbers in this assay, from the lowest: compounds 3, 4, 2 and 1 (each within the scatter of the next).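

In this assay the group of 4 heavy atoms, with its 2 hydrogen-bond donors, on a nitrogen on an aromatic ring gives a 1.1-fold higher number from compound 3 to compound 4 (0.06 log units; within the scatter) against ethyl and a 1.1-fold lower number from compound 2 to compound 4 (0.04 log units; within the scatter) against the phenyl of the anilino compound. Replacing chloro on the aromatic carbon gives a 1.5-fold lower number from compound 1 to compound 4 (0.17 log units; within the scatter) so this non-ring group with sulfur also stays within the scatter, widening the range of groups accepted here. No available evidence explains this flat response.

As far as these compounds go, whether a carboxylic acid, a morpholine ring or a longer alkyl chain on this nitrogen would produce a step beyond the scatter remains open.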